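Three inactive amides and a methylcyclohexyl analogue

The compounds below may be only part of what the source reports. "The series", "measured", "known", "first", "only" and "open" are said of these compounds alone.

The series shares one core, varied only at the acyl group on the amide-type nitrogen in a ring. Compound 1 `O=C(C1CC12CCC2)N1CCc2nc(C#Cc3ccccc3)sc2C1` carries a spiro bicyclic acyl group; in an assay on HEK293 cells for negative allosteric modulation of metabotropic glutamate receptor 5 (Homo sapiens), read by FLIPR, with a stated time of 1 h (a higher number here means a weaker inhibitor, a lower number a stronger inhibitor), compound 1 gives only a limit, > 10000 nM. Compound 2 `O=C(C1CCCO1)N1CCc2nc(C#Cc3ccccc3)sc2C1` carries an oxolanyl group, and in this assay compound 2 likewise gives only a limit, > 10000 nM. Compound 3 `O=C(C1CCC(F)(F)CC1)N1CCc2nc(C#Cc3ccccc3)sc2C1` carries a 4,4-difluorocyclohexyl group, and in this assay compound 3 again gives only a limit, > 10000 nM. The steps between them, a step that the two limits leave unreadable from compound 1 to compound 2, a step that the two limits leave unreadable from compound 1 to compound 3 and a step that the two limits leave unreadable from compound 2 to compound 3, cannot be sized, because all three values sit at the limit of > 10000 nM in this assay, at which 3 of the 3 values shown sit. Compound 4 `CC1CCCC(C(=O)N2CCc3nc(C#Cc4ccccc4)sc3C2)C1` differs from compound 3 by 3-methylcyclohexyl in place of 4,4-difluorocyclohexyl on a carbonyl carbon. Among the compounds with values here, no measured step bears readably on this change, so no shift beyond the scatter can be expected. Compound 4 is therefore expected to give roughly 12000 nM, with a range of 3000 nM to 50000 nM. The expected step from compound 3 to compound 4 is a step that the limit leaves unreadable from compound 3 to compound 4, most likely reported again only as a limit.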

Compound 4, half-maximal inhibitory concentration: > 10000 nM
Compound 4: no number, only a limit (the forecaster's own chance of this, stated with the estimate: 75%); the middle value does not contradict the limit.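

Within the data shown here, compound 4, like compound 1, compound 2 and compound 3, gives only a limit in this assay, so no step from compound 4 to any of them can be read: the limit of > 10000 nM in this assay, at which 4 of the 4 values shown sit. The compounds shown leave open which acyl group, if any, on the shared core would give a measurable value.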